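Swapping tert-butyl for methyl on a cytotoxicity series

This account rests on a few compounds, and the source may have more. Where it says the series, first, only, none or still open, it means among the compounds named here.

Compound 1 `Cc1cccc(-c2nnc(SCCCN3CCN(c4ccccn4)CC3)[nH]2)c1` — in a functional assay on MCF7 cells (Homo sapiens) for cytotoxicity, read by MTT assay, with a stated time of 24 h (on this read-out higher numbers stand for weaker inhibition and lower numbers for stronger inhibition), compound 1 gives > 300000 nM, a limit of the assay.
Compound 2 `CC(C)(C)c1ccc(-c2nn(CCCN3CCN(c4ccccc4)CC3)c(=S)[nH]2)cc1` — in this assay compound 2 gives > 300000 nM, a limit of the assay.
Compound 3 `CC(C)(C)c1ccc(-c2nn(CCCN3CCN(c4cccc(Cl)c4)CC3)c(=S)[nH]2)cc1` — in this assay compound 3 gives > 300000 nM, a limit of the assay.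

Compound 3 therefore stands only at a limit, and so does every other measured compound in this set; none has a number of its own. Going by the values given here, the single step between measured compounds, a step that the two limits leave unreadable from compound 2 to compound 3, runs from one limit to another, so its size cannot be read. What remains is the limit of > 300000 nM in this assay, at which 3 of the 3 values shown sit.

Compound 4 `Cc1ccc(-c2nn(CCCN3CCN(c4cccc(Cl)c4)CC3)c(=S)[nH]2)cc1` differs from compound 3 in one place: methyl in place of tert-butyl on an aromatic carbon. Among the compounds with values here, no measured step bears on this change, since the only step available is unreadable. With every measured compound sitting at the limit, compound 4 is expected to sit there as well, and the step of a number no higher from compound 3 to compound 4 (the limit leaves the size open) is expected to show no change beyond the scatter. Compound 4 is estimated at 300000 nM, within a range of 100000 nM to 1000000 nM, most probably reported again as a limit.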

Compound 4, half-maximal inhibitory concentration: > 300000 nM
Compound 4 gave a limit, no number (the forecaster's own chance of this, stated with the estimate: 85%); the middle value lies on the limit itself.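

Compound 3 and compound 4 both stand at a limit, so the step between them, like every other step here, cannot be read: the limit of > 300000 nM in this assay, at which 4 of the 4 values shown sit. The compounds shown leave open whether methyl in place of tert-butyl changes the read-out at all, and which structure would give a number of its own.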